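Ester to acid on the carboxymethyl arm

A few compounds are considered here, and "the series" means these few. Any claim that something is new, unique, unknown or untested is made for them only; others in the source may bear on it.

Among the measured compounds shown here, compound 2 `CCOC(=O)CN(c1nc(Cl)nc2c1ncn2C1CCCCO1)C1CC1` is one of only two compounds measured so far in a functional assay on the whole organism with Mus musculus as the target, with a stated time of 90 min, at a dose of 25 umol/kg by the oral route (on this read-out lower numbers stand for a weaker effect and higher numbers for a stronger effect at the one dose given), where compound 2 gives 13%. The other, compound 1 `Clc1nc(NC2CC2)c2ncn(C3CCCCO3)c2n1`, gives 11.9% in this assay; the step of a number 1.1 percentage points higher from compound 1 to compound 2 (within the scatter) lies within the scatter, so the two numbers cannot be told apart. Compound 3 `O=C(O)CN(c1nc(Cl)nc2c1ncn2C1CCCCO1)C1CC1` differs from compound 2 in one place: hydrogen in place of ethyl on an oxygen next to a carbonyl group. For the measured compounds named here, no measured step touches this oxygen. Going by the values given here, the only known step, a number 1.1 percentage points higher from compound 1 to compound 2 (within the scatter), added the whole (ethoxycarbonyl)methyl group and moved nothing beyond the scatter, so there is no precedent for removing the ethyl alone. With both measured values close together, the expectation for compound 3 is a step of a number 1 percentage points lower from compound 2 to compound 3 (within the scatter) of no size beyond the scatter. Compound 3 is therefore estimated at 12% in this assay, with a range from 3% to 24%.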

Compound 3, a percentage reported as activity, at one dose (the size of the read-out at that dose, not a potency): 8.22%
For compound 3 the middle estimate is 3.8 percentage points above the measured one, and the stated range covers the measured number.
By their numbers in this assay, from the lowest: compounds 3, 1 and 2 (each within the scatter of the next).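

In this assay, among the compounds shown here, the first measured change on this oxygen gives a number 4.8 percentage points lower from compound 2 to compound 3 (within the scatter), so the ethoxycarbonyl and carboxy forms of the arm cannot be told apart at this dose. Against the hydrogen on the nitrogen, the carboxymethyl arm gives a number 3.7 percentage points lower from compound 1 to compound 3 (within the scatter), so neither the ester nor the acid form of the arm has yet separated from compound 1, and no change at this position has moved the read-out beyond the scatter. Nothing available bears on why these numbers stand as they do.

Still open, going by these compounds, is whether a primary amide or a longer chain such as propyl on this oxygen would leave the read-out as flat. Also open, on these data alone, is whether an amine at the end of the arm would separate from compound 1 beyond the scatter.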